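The compounds below may be only part of what the source reports. "The series", "measured", "known", "first", "only" and "open" are said of these compounds alone.

In a functional assay (plasma) for inhibition, with Rattus norvegicus as the target (on this read-out higher numbers stand for weaker inhibition and lower numbers for stronger inhibition), compound 2 (`C/C(=C\c1ccc(Cc2cncs2)cc1)C(=O)O`) gives 220 nM and sits within the scatter of compound 3 (`O=C(O)c1ccc2c(c1)CC(Cc1cncs1)C2`) at 400 nM while compound 1 (`O=C(O)C1CCc2cc(Cc3cncs3)ccc2C1`) at 1900 nM lies beyond the scatter from compound 2, on the side of weaker inhibition. Compound 2 therefore stands in the better-inhibiting part of this small set, level with compound 3 and clearly apart from compound 1.

Compound 4 (`O=C(O)/C=C/c1ccc(Cc2cncs2)cc1`) differs from compound 2 in one place: on an aromatic carbon, para to a (1,3-thiazol-5-yl)methyl group, 2-carboxyethenyl stands in place of 2-carboxyprop-1-en-1-yl (2-carboxyethenyl in place of 2-carboxyprop-1-en-1-yl on an aromatic carbon). Among the measured compounds shown here, no measured pair isolates this change, so the expectation rests on compound 2 at 220 nM as the starting point, with a wide margin. The expected step is small, a 1.4-fold higher number from compound 2 to compound 4 (0.13 log units; within the scatter) in this assay, leaning towards a higher number but not expected to pass beyond the scatter. For compound 4 the estimated value is 300 nM, with an expected range from 100 nM to 900 nM.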

Compound 4, half-maximal inhibitory concentration: 1500 nM
For compound 4 the middle estimate is 5.0-fold (0.70 log units) below the measured one; the whole stated range lies below it.
By their numbers in this assay, from the lowest: compounds 2 and 3 (each within the scatter of the next); then compounds 4 and 1 (each within the scatter of the next).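

Among the compounds shown here, this is the first comparison in the set that isolates a single change: on the aromatic carbon para to a (1,3-thiazol-5-yl)methyl group, 2-carboxyethenyl in place of 2-carboxyprop-1-en-1-yl gives, in this assay, a 6.8-fold higher number from compound 2 to compound 4 (0.83 log units; beyond the scatter) towards weaker inhibition. The two groups have the same counts of double bonds, hydrogen-bond donors and hydrogen-bond acceptors and differ in heavy atoms, 5 against 6, so this position responds beyond the scatter to a small difference in the group it carries. Nothing available accounts for the size of this step.

The compounds shown leave open whether a larger chain, such as 2-carboxybut-1-en-1-yl, would move the number further in the same direction. They also leave open whether the carboxylic acid itself is needed, as a primary amide on the same chain would test.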